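Series notes: glycinamide-linked amino acid esters in tail flick

The compounds below may be only part of what the source reports. "The series", "measured", "known", "first", "only" and "open" are said of these compounds alone.

Measured compounds:
compound 1 `C[C@@H](O)[C@H](NC(=O)CN(c1nc(Cl)nc2[nH]cnc12)C1CC1)C(=O)O`: 35.9%
compound 2 `CC[C@H](C)[C@H](NC(=O)CN(c1nc(Cl)nc2[nH]cnc12)C1CC1)C(=O)OCc1ccccc1`: 36.3%
compound 3 `CC(C)[C@H](NC(=O)CN(c1ncnc2c1ncn2C1CCCCO1)C1CC1)C(=O)OCc1ccccc1`: 30.1%

In a functional assay on the whole organism (Tail, strain ICR) with Mus musculus as the target, in the tail flick test, with a stated time of 90 min, at a dose of 25 umol/kg by the oral route (on this read-out lower numbers stand for a weaker effect and higher numbers for a stronger effect at the one dose given), compound 2 gives 36.3%, the largest of the three numbers, yet its gap to compound 1 and its gap to compound 3 both lie within the scatter, so the three measured compounds cannot be told apart on this read-out. Within the data shown here, no step between two measured compounds differing in one place is available, so nothing about the effect of a single change has been measured in this set.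

Compound 4 `NC(=O)CC[C@H](NC(=O)CN(c1nc(Cl)nc2[nH]cnc12)C1CC1)C(=O)OCc1ccccc1` is to be measured. Relative to compound 2 the change is 2-carbamoylethyl in place of sec-butyl on a saturated chain carbon bound to an amide-type nitrogen and a carbonyl carbon. Among the measured compounds shown here, with no measured step to go by, and with all three measured numbers sitting close together, the expectation is of no step beyond the scatter in this assay, with a slight lean toward a weaker read-out. Compound 4 is thus expected to give 32%, with a likely range from 20% to 45%. The estimated step is a number 4.3 percentage points lower from compound 2 to compound 4 (within the scatter).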

Compound 4, a percentage reported as activity, at one dose (the size of the read-out at that dose, not a potency): 42.8%
Estimate against measurement, compound 4: 10.8 percentage points below; measured number inside the range.
By their numbers in this assay, from the lowest: compounds 3, 1, 2 and 4 (each within the scatter of the next, the first and the last beyond it).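

In this assay, among these compounds, the change of sec-butyl to 2-carbamoylethyl on a saturated chain carbon bound to an amide-type nitrogen and a carbonyl carbon gives the first single-place step, a number 6.5 percentage points higher from compound 2 to compound 4 (within the scatter). The read-out at this position therefore stays within the scatter when an all-carbon branched group gives way to an unbranched chain ending in a primary amide, with one hydrogen-bond donor and one hydrogen-bond acceptor entering. No other measurement bears on this step, so it stands without an explanation.

One step at a single dose cannot show how far this position stays permissive. A primary amine on the chain, or a longer chain carrying the same terminal amide, would test whether the read-out stays equally flat at this position.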